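This account rests on a few compounds, and the source may have more. Where it says the series, first, only, none or still open, it means among the compounds named here.

Measured so far:

Compound 1 `Nc1cc(N)c2nc(-c3ccccc3)c(Oc3ccc(Cl)c(Cl)c3)nc2c1` — in a functional assay on CAKI-1 cells (Homo sapiens) for inhibition, read by sulforhodamine B assay, with a stated time of 48 h (a lower number here means a stronger inhibitor of growth, a higher number a weaker inhibitor of growth), compound 1 gives < 100000 nM, which is a limit of the assay rather than a number.
Compound 2 `Nc1cc(N)c2nc(-c3ccccc3)c(NCc3ccc(Cl)c(Cl)c3)nc2c1` — in this assay compound 2 gives 52500 nM.
Compound 3 `CCOC(=O)[C@H](CCC(=O)O)NC(=O)c1ccc(Oc2nc3cc(N)cc(N)c3nc2-c2ccccc2)cc1` — in this assay compound 3 gives 8710 nM.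

Of the two real numbers, compound 2 stands highest, so it is the weaker growth inhibitor of the two; compound 3 lies a good way lower, and that gap is beyond the usual scatter. Compound 1 contributes only a limit of < 100000 nM in this assay, at which 1 of the 3 values shown sits, and cannot be ranked against them.

Compound 4 `Nc1cc(N)c2nc(-c3ccccc3)c(NCc3ccc(F)cc3)nc2c1` differs from compound 2 in a single place: 4-fluorophenyl in place of 3,4-dichlorophenyl on a saturated chain carbon bound to a nitrogen on an aromatic ring. Within the data shown here, no measured pair in this set shows a change of this kind, so the size of the step can only be expected, not read off. The expectation is a step of a 1.3-fold higher number from compound 2 to compound 4 (0.12 log units; within the scatter), a small weakening that may not rise beyond the scatter. Compound 4 is therefore expected to give about 70000 nM in this assay, within a range from 25000 nM to 200000 nM.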

Compound 4, concentration for total growth inhibition: 37200 nM
Beside the measured number, compound 4's estimate is 1.9-fold (0.27 log units) above it, and the stated range covers the measured number.
By their numbers in this assay, from the lowest: compound 3; then compounds 4 and 2 (each within the scatter of the next).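

Among these compounds, replacing 3,4-dichlorophenyl with 4-fluorophenyl on a saturated chain carbon bound to a nitrogen on an aromatic ring gives the first readable step at this position: a 1.4-fold lower number from compound 2 to compound 4 (0.15 log units; within the scatter). In this assay, the two compounds therefore cannot be told apart, so this exchange of halogen-bearing rings, which also removes one heavy atom, leaves the number within the scatter. Compound 1 gives only a limit, so the step from compound 1 to compound 4, which would compare the linking groups, cannot be read: the limit of < 100000 nM in this assay, at which 1 of the 4 values shown sits.

Going by these compounds, both rings tested here carry halogens, so it remains open whether a plain benzyl group or a ring bearing an amine or a carboxylic acid would move the number beyond the scatter. A longer chain between the nitrogen and the ring is equally untested among the compounds shown.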